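Chloro for propyl on the cinnamide aryl ring

The source may hold more compounds than are shown below. What is called first, only, known or untested is meant among the compounds shown, and "the series" means these compounds.

Compound 1 `CCCc1ccc(/C=C/C(=O)Nc2ccc3nc(CCC)cc(N)c3c2)cc1` carries a propyl group on the phenyl ring of its cinnamide. In an assay on isolated protein for displacement of a labelled ligand from melanin-concentrating hormone receptor 1 (Homo sapiens) (a higher number here means a weaker inhibitor, a lower number a stronger inhibitor), compound 1 gives 4 nM, the highest number among the three measured. Compound 2 `CCCc1cc(N)c2cc(NC(=O)c3ccc(-c4ccc(Cl)cc4)cc3)ccc2n1` gives 0.7 nM and compound 3 `Nc1cc(C2CCCCC2)nc2ccc(NC(=O)/C=C/c3ccc(C(F)(F)F)cc3)cc12` gives 1.2 nM; both gaps to compound 1 lie beyond the scatter, so compound 1 is the weakest inhibitor of the three. Compound 4 `CCCc1cc(N)c2cc(NC(=O)/C=C/c3ccc(Cl)cc3)ccc2n1` is not yet measured and differs from compound 1 in one place: chloro in place of propyl on an aromatic carbon. Going by the values given here, no single-point step between measured compounds exists, so the direction rests on analogy: compound 2, with its chloro on an outer phenyl ring, shows 0.7 nM. A modest move to a lower number is expected, a 2.0-fold lower number from compound 1 to compound 4 (0.30 log units; within the scatter). Compound 4 is estimated at 2 nM, range 0.7 nM to 6 nM.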

Compound 4, half-maximal inhibitory concentration: 6 nM
Compound 4: middle estimate off by 3.0-fold (0.48 log units), on the low side; the range from low to high includes it.
By their numbers in this assay, from the lowest: compounds 2 and 3 (each within the scatter of the next); then compounds 1 and 4 (each within the scatter of the next).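

Going by these compounds alone, the first one-place step in this assay reads a 1.5-fold higher number from compound 1 to compound 4 (0.18 log units; within the scatter) on going from 4-propylphenyl to 4-chlorophenyl. On this aromatic carbon, a single chlorine can stand in for the three carbons of propyl without separating the two compounds in this pair. Nothing available explains why the two groups read alike.

As far as these compounds go, whether an amine, a methoxy group or a carboxylic acid on the same carbon would also stay within the scatter of compound 1 remains open. The same holds for a longer chain such as hexyl.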